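The source may hold more compounds than are shown below. What is called first, only, known or untested is meant among the compounds shown, and "the series" means these compounds.

The three compounds share one core and differ only in the group on the amine nitrogen. In a functional assay on A-431 cells (Homo sapiens) for cytotoxicity, read by MTT assay, with a stated time of 48 h (on this read-out lower numbers stand for stronger inhibition and higher numbers for weaker inhibition), compound 1 `CCCCCCCCCCCCNC(=O)[C@@H](NC(=O)c1cccs1)[C@@H](C)O` gives 16600 nM. Compound 2 `CCCCCCCCCCCCNC(=O)[C@@H](NC(=O)c1cc2ccccc2o1)[C@@H](C)O` gives 20000 nM in this assay, and compound 3 `CCCCCCCCCCCCNC(=O)[C@@H](NC(=O)c1cc2ccccc2[nH]1)[C@@H](C)O` gives 10300 nM. All three lie within the scatter of one another: a 1.2-fold higher number from compound 1 to compound 2 (0.08 log units; within the scatter), a 1.6-fold lower number from compound 1 to compound 3 (0.21 log units; within the scatter), and a 1.9-fold lower number from compound 2 to compound 3 (0.29 log units; within the scatter). On these numbers compound 1 stands second highest of the three, nearest to compound 2 and furthest from compound 3, yet within the scatter of both.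

Compound 4 `CCCCCCCCCCCCNC(=O)[C@@H](NS(=O)(=O)c1cccs1)[C@@H](C)O` differs from compound 1 by (thiophen-2-yl)sulfonyl in place of (thiophen-2-yl)carbonyl on an amine nitrogen. For the measured compounds named here, none of the measured steps bears on this exchange: each of them swaps one aromatic ring for another on the carbonyl carbon and leaves the carbonyl itself in place, and each stayed within the scatter. With nothing in the data that speaks to this change, the step of a 1.1-fold higher number from compound 1 to compound 4 (0.04 log units; within the scatter) is expected to be no larger than the scatter, though the range must be wide. Compound 4 is therefore estimated at 18000 nM, between 6000 nM and 50000 nM.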

Compound 4, half-maximal inhibitory concentration: 22000 nM
Estimate against measurement, compound 4: 1.2-fold (0.09 log units) below, and the stated range covers the measured number.
By their numbers in this assay, from the lowest: compounds 3, 1, 2 and 4 (each within the scatter of the next, the first and the last beyond it).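

Every earlier step swapped one aromatic ring for another and kept the carbonyl, whereas this one keeps the thiophen-2-yl ring and replaces the carbonyl itself with a sulfonyl on the amine nitrogen. In this assay the exchange gives a 1.3-fold higher number from compound 1 to compound 4 (0.12 log units; within the scatter), so at this position the link to the ring, like the ring itself, can change without moving the number beyond the scatter. No measurement at hand speaks to why this is so.

From the compounds shown here alone, whether the same exchange behaves alike with the 1H-indol-2-yl or 1-benzofuran-2-yl ring stays open. So does the outcome with a group that has no aromatic ring on this nitrogen, such as a simple acetyl or a chain ending in an amine or a carboxylic acid.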